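The source may hold more compounds than are shown below. What is called first, only, known or untested is meant among the compounds shown, and "the series" means these compounds.

Measured in a functional assay on the whole organism with Mus musculus as the target; on this read-out higher numbers stand for an effect only at larger amounts of compound and lower numbers for an effect already at smaller amounts:
- compound 1 `CC(C)=Cc1c(C)c(N)c(C)c2c1OC(C)(C)C2` gives 21.9 mg/kg
- compound 2 `Cc1c(C)c2c(c(C)c1N)CC(C)(CSc1ccc(F)cc1)O2` gives 17.9 mg/kg
- compound 3 `CCCSCC1(C)Cc2c(C)c(N)c(C)c(C)c2O1` gives 24.6 mg/kg

The three numbers lie within the scatter of one another, so compound 3 is not set apart from compound 1 or from compound 2. For the measured compounds named here, the one step that can be read between single-point neighbours is a 1.4-fold higher number from compound 2 to compound 3 (0.14 log units; within the scatter), and it stays within the scatter.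

Compound 4 `Cc1c(C)c2c(c(C)c1N)CC(C)(CCN1CCCCC1)O2` has not been measured. It differs from compound 3 as follows: (piperidin-1-yl)methyl in place of propylsulfanyl on a saturated chain carbon bound to a saturated ring carbon. Going by the values given here, no measured pair shows this change, or one like it, on the shared core; the only neighbouring step, from compound 2 to compound 3, concerns a different group on a sulfur and was within the scatter. With nothing in the data pointing either way, compound 3 is taken as the reference and compound 4 is expected to give about the same number, a step of a 1.0-fold lower number from compound 3 to compound 4 (0.01 log units; within the scatter) that is not expected to exceed the scatter. Compound 4 is therefore estimated at 24 mg/kg in this assay, with a range from 9 mg/kg to 65 mg/kg.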

Compound 4, dose for 50% inhibition: 18.4 mg/kg
Compound 4: middle estimate off by 1.3-fold (0.12 log units), on the high side; measured number inside the range.
By their numbers in this assay, from the lowest: compounds 2, 4, 1 and 3 (each within the scatter of the next).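

In this assay, for the compounds shown here, the chain carbon bound to the saturated ring carbon had so far been seen only with groups on a sulfur, and (piperidin-1-yl)methyl in place of propylsulfanyl gives a 1.3-fold lower number from compound 3 to compound 4 (0.13 log units; within the scatter). Among the compounds shown, a sulfur at this place is therefore not needed for a number in this range, and a six-membered non-aromatic ring with a nitrogen can stand there without a change that can be told from the scatter. Nothing available bears on why the number holds across this exchange.

The compounds shown leave open how this place responds to an open-chain amine such as dimethylaminomethyl, to a carboxylic acid, or to a longer chain carrying the piperidine. They also leave open whether any group here can move the number beyond the scatter, as every step shown stays within it.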